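Methoxy gives way to chloro on compound 2

A few compounds are considered here, and "the series" means these few. Any claim that something is new, unique, unknown or untested is made for them only; others in the source may bear on it.

Compound 1 `COCCn1cc(C(=O)C(=O)Nc2ccc(OCC(=O)O)nc2)c2ccccc21` gives (> 10000 nM), a limit of the assay
Compound 2 `COc1ccc(NC(=O)C(=O)c2cn(C(C)C)c3cccc(OC)c23)cn1` gives (7780 nM)

For the measured compounds named here, in a functional assay on FaDu cells (Homo sapiens) for cytotoxicity, read by MTT assay, with a stated time of 72 h (a lower number here means that less compound is tolerated, a higher number that more compound is tolerated), compound 2 holds the only true number, since the entry for compound 1 is a limit. Compound 3 `COc1ccc(NC(=O)C(=O)c2cn(C(C)C)c3cccc(Cl)c23)cn1` has chloro in place of methoxy on an aromatic carbon, ortho to a fused ring and meta to a fused ring (chloro in place of methoxy on an aromatic carbon). Going by the values given here, no measured step shows what this exchange does, so the expectation starts from the value of compound 2 (7780 nM). The expected step is small (a 1.3-fold lower number from compound 2 to compound 3 (0.11 log units; within the scatter)). For compound 3 the estimated value is 6000 nM, with an expected range from 2000 nM to 10000 nM.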

Compound 3, concentration lethal to 50% of the cells: 2130 nM
Estimate against measurement, compound 3: 2.8-fold (0.45 log units) above, within the range that was stated.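

In this assay, the aromatic carbon ortho to a fused ring and meta to a fused ring proves sensitive to its substituent: chloro in place of methoxy gives a 3.7-fold lower number from compound 2 to compound 3 (0.56 log units; beyond the scatter). This is the only step shown between compounds that differ in one place, so it gives the first reading of this position. Nothing shown offers a cause for the step. On these data alone, whether fluoro, a longer alkoxy chain or an amine on this carbon would move the number further remains open.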